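This account rests on a few compounds, and the source may have more. Where it says the series, first, only, none or still open, it means among the compounds named here.

Measured so far: compound 1 `Cc1nnc(S)n2cncc12` and compound 2 `CCCc1ncc2c(C)nnc(SC)n12`. In a functional assay for inhibition, with Homo sapiens as the target (on this read-out lower numbers stand for stronger inhibition and higher numbers for weaker inhibition), compound 1 reaches only the limit of the assay, > 48000 nM. Compound 2 likewise returns only a limit, > 48000 nM. Compound 2 therefore stands at the ceiling of the numbers shown, with no measured step to set beside it; (the limit of > 48000 nM in this assay, at which 2 of the 2 values shown sit). Compound 3 `CCCc1ncc2c(C)nnc(S)n12` carries the change (hydrogen in place of methyl on a sulfur), hydrogen in place of methyl on a sulfur. With both shown values sitting at the limit, no step beyond the scatter is expected in this assay in either direction, and a further limit is the likely outcome. Compound 3 is estimated at 60000 nM (range 20000 nM to 200000 nM), meaning an expected step that the limit leaves unreadable from compound 2 to compound 3.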

Compound 3, half-maximal inhibitory concentration: > 48000 nM
Compound 3 ended at the assay's limit; the forecaster's own chance of this, stated with the estimate: 85%; the middle value does not contradict the limit.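

No step can be read among compound 1, compound 2 and compound 3 in this assay: the limit of > 48000 nM in this assay, at which 3 of the 3 values shown sit.

The compounds shown leave open whether the sulfanyl, methylsulfanyl or propyl groups alter inhibition at all in this assay, as no measured number lies under the limit.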